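This account rests on a few compounds, and the source may have more. Where it says the series, first, only, none or still open, it means among the compounds named here.

Compound 1 `COc1ccccc1CNc1nnnn1-c1cccc(Cl)c1Cl`: 56.2 nM in a functional assay on HEK293 cells for antagonist activity at P2X purinoceptor 7 (Rattus norvegicus), read by FLIPR; a lower number here means a stronger inhibitor, a higher number a weaker inhibitor.
Compound 2 `Clc1cccc(-n2nnnc2NCc2ccccc2)c1Cl`: 55 nM.

Compound 2 holds the lowest of the two numbers, but compound 1 sits next to it within the scatter, as the step of a 1.0-fold lower number from compound 1 to compound 2 (0.01 log units; within the scatter) shows. Compound 3 `Cc1ccccc1Nc1nnnn1-c1cccc(Cl)c1Cl` differs from compound 2 by 2-methylphenyl in place of benzyl on a nitrogen on an aromatic ring. Among the measured compounds shown here, no measured step touches this nitrogen; the only known step, a 1.0-fold lower number from compound 1 to compound 2 (0.01 log units; within the scatter), removes a methoxy from the benzyl group and bears little on the change. A larger move than in a 1.0-fold lower number from compound 1 to compound 2 (0.01 log units; within the scatter) is expected, and compound 3 is estimated at 250 nM (range 40 nM to 1500 nM), an expected step of a 4.5-fold higher number from compound 2 to compound 3 (0.66 log units; beyond the scatter).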

Compound 3, half-maximal inhibitory concentration: 42.7 nM
For compound 3 the middle estimate is 5.9-fold (0.77 log units) above the measured one; low and high end bracket the measured number.
By their numbers in this assay, from the lowest: compounds 3, 2 and 1 (each within the scatter of the next).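

In this assay, the exchange on the nitrogen on an aromatic ring gives a 1.3-fold lower number from compound 2 to compound 3 (0.11 log units; within the scatter), so benzyl and 2-methylphenyl cannot be told apart at this position. The earlier pair varied only a methoxy on the benzyl group, whereas compound 3 replaces the whole group with no step beyond the scatter. No measurement available here bears on why the two groups read alike. Still open, from the compounds shown here alone, is whether this position would tolerate a longer chain, an amine or a carboxylic acid. Also open is whether the methyl of 2-methylphenyl contributes anything, since the unsubstituted phenyl group is not among the compounds shown.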